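A 2-Phenylethenyl Swap in a Weakly Active Trio

This account rests on a few compounds, and the source may have more. Where it says the series, first, only, none or still open, it means among the compounds named here.

In a functional assay on Z-138 cells (Homo sapiens) for antiproliferative activity, with a stated time of 72 h (on this read-out higher numbers stand for weaker inhibition and lower numbers for stronger inhibition), compound 1 `Nc1ncnn2c([C@@H]3O[C@H](CO)[C@@H](O)[C@H]3O)cc(C#Cc3ccc(F)cc3)c12` gives 89000 nM, compound 2 `Nc1ncnn2c([C@@H]3O[C@H](CO)[C@@H](O)[C@H]3O)cc(C#Cc3cccs3)c12` gives 50100 nM and compound 3 `Nc1ncnn2c([C@@H]3O[C@H](CO)[C@@H](O)[C@H]3O)cc(-c3ccc(F)cc3F)c12` gives 59100 nM. Compound 3 sits level with the other two, as every gap among the three lies within the usual scatter of repeated measurements.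

Compound 4 `Nc1ncnn2c([C@@H]3O[C@H](CO)[C@@H](O)[C@H]3O)cc(/C=C/c3ccccc3)c12` keeps the shared core but carries 2-phenylethenyl in place of 2,4-difluorophenyl on an aromatic carbon. Earlier changes to the group at this carbon moved the number very little, with a 1.5-fold lower number from compound 1 to compound 3 (0.18 log units; within the scatter) and a 1.2-fold higher number from compound 2 to compound 3 (0.07 log units; within the scatter). Changing only the ring on the triple-bonded carbon gave a 1.8-fold lower number from compound 1 to compound 2 (0.25 log units; within the scatter). Going by these compounds, none of the three measured compounds has a double bond outside aromatic rings, so the new link remains untested. The expected result in this assay is no shift beyond the scatter: a 1.2-fold lower number from compound 3 to compound 4 (0.07 log units; within the scatter). For compound 4 the estimated value is 50000 nM, with an expected range from 15000 nM to 100000 nM.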

Compound 4, half-maximal inhibitory concentration: 1300 nM
Compound 4: the middle estimate sits 38-fold (1.59 log units) above what was measured, and the stated range ends above it.
By their numbers in this assay, from the lowest: compound 4; then compounds 2, 3 and 1 (each within the scatter of the next).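

In this assay the group on this aromatic carbon proves able to move the number strongly, which the earlier swaps, all within the scatter, gave no sign of: 2-phenylethenyl brings a 45-fold lower number from compound 3 to compound 4 (1.66 log units; beyond the scatter) and also a 39-fold lower number from compound 2 to compound 4 (1.59 log units; beyond the scatter) and a 68-fold lower number from compound 1 to compound 4 (1.84 log units; beyond the scatter) at the same carbon. Heavy-atom count does not separate the two groups exchanged between compound 3 and compound 4, while the entering group adds a double bond outside aromatic rings and has no fluorine. Nothing available explains the large gain.

Compound 4 differs from the others in both its link and its ring, so the double bond and the unsubstituted phenyl ring cannot be told apart. A 2-(4-fluorophenyl)ethenyl group, or a saturated 2-phenylethyl chain, would test each part separately.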